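Aryl substituent series on the shared core, Bcl-2 binding

The source may report more compounds than this note shows. Statements on the series, on what has been measured and on what is new or still open speak of the compounds shown alone.

Compound 1 `CCOC(=O)C1=C(N)Oc2ccc(C3CCCC3)cc2C1C(C#N)C(=O)OCC`: 128000 nM
Compound 2 `CCOC(=O)C1=C(N)Oc2ccccc2C1C(C#N)C(=O)OCC`: 531000 nM

Both were run in an assay on isolated protein for binding affinity to Apoptosis regulator Bcl-2 (Homo sapiens), read by fluorescence polarization; on this read-out higher numbers stand for weaker inhibition and lower numbers for stronger inhibition. Compound 2 gives the highest of the two numbers, the nearest being compound 1, with hydrogen in place of cyclopentyl on an aromatic carbon giving a 4.1-fold higher number from compound 1 to compound 2 (0.62 log units; beyond the scatter).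

Compound 3 `CCOC(=O)C1=C(N)Oc2ccc(C)cc2C1C(C#N)C(=O)OCC` differs from compound 2 by methyl in place of hydrogen on an aromatic carbon, meta to a fused ring and para to a fused ring. Going by the values given here, only the step from compound 1 to compound 2 bears on this change; the entering group here is smaller, so a lower number than compound 2 is expected, with a smaller drop. Compound 3 is therefore expected to show a 1.8-fold lower number from compound 2 to compound 3 (0.25 log units; within the scatter). Compound 3 is estimated at 300000 nM, between 120000 nM and 700000 nM.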

Compound 3, inhibition constant: 309000 nM
Compound 3: the middle estimate sits 1.0-fold (0.01 log units) below what was measured; the range from low to high includes it.
By their numbers in this assay, from the lowest: compound 1; then compounds 3 and 2 (each within the scatter of the next).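

Methyl in place of hydrogen gives a 1.7-fold lower number from compound 2 to compound 3 (0.24 log units; within the scatter) and so does not separate from hydrogen at this position. Cyclopentyl does separate from methyl here, with methyl in its place giving a 2.4-fold higher number from compound 1 to compound 3 (0.38 log units; beyond the scatter) and leaving compound 1 apart from the other two. Nothing at hand explains this difference.

As far as these compounds go, whether the lower number of compound 1 depends on a ring or simply on more carbon atoms stays open. An ethyl group, a longer chain or a phenyl ring would address that, while an amine or a carboxylic acid at this position remains untested ground in the compounds shown.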